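The source may hold more compounds than are shown below. What is called first, only, known or untested is meant among the compounds shown, and "the series" means these compounds.

Compound 1, `CC(O)c1cnc(N2CCC(c3coc4c(N5CCc6cc(S(C)(=O)=O)ccc65)ncnc34)CC2)nc1`, is the weaker of the two measured compounds: in a functional assay on cells for agonist activity at Glucose-dependent insulinotropic receptor (Homo sapiens), read by a luciferase reporter, with a stated time of 4 h (on this read-out higher numbers stand for larger maximal responses and lower numbers for smaller maximal responses), compound 1 reaches 33%. Within the data shown here, compound 2, `CC(C)(C)OC(=O)N1CCC(c2noc3c(Nc4ccc(S(C)(=O)=O)cc4F)ncnc23)CC1`, is built on a different core and reaches 137% in this assay, a gap that lies well beyond the usual scatter; with no single-point step between these two, the pair shows only that the compounds span a wide range of maximal response.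

Compound 3, `CS(=O)(=O)c1ccc2c(c1)CCN2c1ncnc2c(C3CCN(c4ncc(F)cn4)CC3)coc12`, keeps the core of compound 1 and differs from it in one place: fluoro in place of 1-hydroxyethyl on an aromatic carbon. Among the measured compounds shown here, no measured pair shows the effect of this change on the present core, so the expectation rests on compound 1 alone. He expects a modest step, a number 7 percentage points higher from compound 1 to compound 3 (within the scatter), that need not leave the scatter. Compound 3 is therefore estimated to reach 40% in this assay, within a range of 15% to 80%.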

Compound 3, largest response reached (Emax), in percent of the reference or control that the assay uses: 229%
Estimate against measurement, compound 3: 189 percentage points below, and the stated range ends below it.
By their numbers in this assay, from the lowest: compound 1; then compound 2; then compound 3.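

In this assay, replacing 5-(1-hydroxyethyl)pyrimidin-2-yl with 5-fluoropyrimidin-2-yl on the shared core gives a number 196 percentage points higher from compound 1 to compound 3 (beyond the scatter). Among these compounds, this is the first single-place step, and it shows that the group on this aromatic carbon, para to a large group, can by itself change the maximal response by far more than the usual scatter. Nothing measured here bears on why the step is so large.

The change removes the hydroxyl and the carbons of the 1-hydroxyethyl together, and the compounds shown cannot separate their contributions. On these data alone, it remains open where a chloro, methoxy, ethyl or amino group at this position would fall relative to compound 1 and compound 3, and whether the step would carry over to another core.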